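The source may hold more compounds than are shown below. What is called first, only, known or untested is meant among the compounds shown, and "the series" means these compounds.

Measured so far in a functional assay on HCT-116 cells (Homo sapiens) for antiproliferative activity, read by MTT assay, with a stated time of 48 h; a higher number here means a weaker inhibitor, a lower number a stronger inhibitor:

- compound 1 `CCCCCCC(CCO)n1cnc2c(NC)ncnc21` gives > 50000 nM (a limit of the assay, not a number)
- compound 2 `CCCCCCCCC(CCO)n1cnc2c(Cl)ncnc21` gives 1650 nM
- compound 3 `CCCCCCCCC(CCO)n1cnc2c(NC)ncnc21` gives 3730 nM

The higher of the two actual numbers in this assay belongs to compound 3, and the step separating the pair is a 2.3-fold higher number from compound 2 to compound 3 (0.35 log units; beyond the scatter). That step, methylamino in place of chloro, does not touch the chain and carries little weight here.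

The next structure is compound 4 `CCCCCCCCCCC(CCO)n1cnc2c(NC)ncnc21`, and the change is ethyl in place of hydrogen on a saturated chain carbon, nine bonds along the chain from an aromatic nitrogen. Within the data shown here, the one measured step of the same kind, ethyl in place of hydrogen seven bonds along the chain from an aromatic nitrogen, is an at least 13-fold lower number from compound 1 to compound 3 (1.12 log units; beyond the scatter). It starts from a limit. A single step cannot show how far the trend runs, so a further but much smaller fall in the number is expected, and a rise is not excluded. The expected step is a 2.1-fold lower number from compound 3 to compound 4 (0.32 log units; beyond the scatter). For compound 4 the estimated value is 1800 nM, with an expected range from 600 nM to 6000 nM.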

Compound 4, half-maximal inhibitory concentration: 12700 nM
Estimate against measurement, compound 4: 7.1-fold (0.85 log units) below; measured number outside the range, above it.
By their numbers in this assay, from the lowest: compound 2; then compound 3; then compound 4. At a limit, above all of these: compound 1.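

In this assay the chain effect at this position does not run in one direction: after an at least 13-fold lower number from compound 1 to compound 3 (1.12 log units; beyond the scatter), the further ethyl in place of hydrogen, nine bonds along the chain from an aromatic nitrogen, reverses the trend, with a 3.4-fold higher number from compound 3 to compound 4 (0.53 log units; beyond the scatter), leaving compound 3 with the lowest number of the three methylamino compounds. Compound 4 nonetheless keeps part of the earlier gain, with an at least 3.9-fold lower number from compound 1 to compound 4 (0.59 log units; beyond the scatter). Compound 1 stands at a limit of the assay, not a number: the limit of > 50000 nM in this assay, at which 1 of the 4 values shown sits.

Chains of intermediate length and a longer chain remain open, so the lowest number is placed only among these three methylamino compounds. Also open, on these data alone, are whether chloro on the chain of compound 4 would differ from methylamino as in a 2.3-fold higher number from compound 2 to compound 3 (0.35 log units; beyond the scatter), and how an amine or a carboxylic acid in place of the hydroxyl would read.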